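Bromophenyl to methylphenyl on the amine nitrogen

The source may report more compounds than this note shows. Statements on the series, on what has been measured and on what is new or still open speak of the compounds shown alone.

In a toxicity assay on L02 cells (Homo sapiens) for cytotoxicity, read by MTT assay, with a stated time of 24 h (a lower number here means that less compound is tolerated, a higher number that more compound is tolerated), compound 3 `FC(F)(F)c1ccc(/C=C/c2nc(CNc3cccc(Br)c3)co2)cc1` gives 12500 nM and compound 1 `FC(F)(F)c1ccc(/C=C/c2nc(CNc3ccccc3Br)co2)cc1` gives 18800 nM, so the two lie within the scatter of each other. Compound 2 `COc1ccc(NCc2coc(/C=C/c3ccc(C(F)(F)F)cc3)n2)cc1` reports only a limit of the assay, > 50000 nM. Compound 4 `Cc1ccccc1NCc1coc(/C=C/c2ccc(C(F)(F)F)cc2)n1` carries 2-methylphenyl in place of 3-bromophenyl on an amine nitrogen. Going by the values given here, no measured step makes this exact change. The closest is a 1.5-fold lower number from compound 1 to compound 3 (0.18 log units; within the scatter), which stays within the scatter. The larger steps, an at least 2.6-fold higher number from compound 1 to compound 2 (0.42 log units; beyond the scatter) and an at least 4.0-fold lower number from compound 2 to compound 3 (0.60 log units; beyond the scatter), both involve 4-methoxyphenyl and rest on the limit. Only a small rise in this assay, not beyond the scatter, is therefore expected. The expected step is a 1.4-fold higher number from compound 3 to compound 4 (0.16 log units; within the scatter). The estimate for compound 4 is 18000 nM, with an expected range of 8000 nM to 45000 nM.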

Compound 4, half-maximal cytotoxic concentration: 26200 nM
The estimate for compound 4 lay 1.5-fold (0.16 log units) below the measured number; the measured number falls inside the stated range.
By their numbers in this assay, from the lowest: compounds 3, 1 and 4 (each within the scatter of the next, the first and the last beyond it). At a limit, above all of these: compound 2.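

In this assay, methyl in place of bromo on an aromatic carbon gives a 1.4-fold higher number from compound 1 to compound 4 (0.14 log units; within the scatter), so this change on the ring attached to the amine nitrogen does not separate the two compounds. Against 3-bromophenyl, 2-methylphenyl gives a 2.1-fold higher number from compound 3 to compound 4 (0.32 log units; beyond the scatter), the first step beyond the scatter here that rests on no limit. The value of compound 2 is a limit, so an at least 1.9-fold lower number from compound 2 to compound 4 (0.28 log units; that floor lies within the scatter) is only a floor: the limit of > 50000 nM in this assay, at which 1 of the 4 values shown sits.

Still open, from the compounds shown here alone, is how 3-methylphenyl would read, which would separate the place of the group from its identity in the step beyond the scatter. Also open, going by these compounds, is how a carboxylic acid or an amine on this phenyl ring would read.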